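Anilino for phenoxy: the solubility outlook for compound 4

The compounds below may be only part of what the source reports. "The series", "measured", "known", "first", "only" and "open" are said of these compounds alone.

Measured so far:
- compound 1, `Fc1ccc2c(c1CNc1ncc(Oc3ccccc3)c3nncn13)CCO2`: 8000 nM
- compound 2, `Cc1ncccc1-c1cnc(NCc2c(F)ccc3c2CCO3)n2c(=O)[nH]nc12`: a limit, < 2000 nM
- compound 3, `Cc1nn(C)cc1-c1cnc(NCc2c(F)ccc3c2CCO3)c2cn[nH]c(=O)c12`: 9000 nM

In a physicochemical assay for solubility, read by LC-MS, in phosphate buffer, with a stated time of 24 h, at pH 7.4 (on this read-out lower numbers stand for lower solubility and higher numbers for higher solubility), compound 1 gives 8000 nM. Compound 3, with a different core, gives 9000 nM in this assay, and the two numbers lie within the usual scatter of each other. Compound 2 gives only a limit in this assay, < 2000 nM, at the limit of < 2000 nM in this assay, at which 1 of the 3 values shown sits, and so supplies no number to place compound 1 against. Within the data shown here, compound 1 therefore stands on a par with the one other measured number, and above the one limit.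

Compound 4, `Fc1ccc2c(c1CNc1ncc(Nc3ccccc3)c3nncn13)CCO2`, differs from compound 1 in one place: anilino in place of phenoxy on an aromatic carbon. Among the measured compounds shown here, no measured pair in this set changes that group, so there is no measured step to lean on. The hydrogen-bond donor that enters is the only counted difference, and the account expects a step from compound 1 to compound 4 of modest size in this assay, most likely within or just beyond the scatter: a 1.3-fold lower number from compound 1 to compound 4 (0.12 log units; within the scatter). Compound 4 is estimated at 6000 nM, between 2000 nM and 18000 nM.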

Compound 4, solubility: 3000 nM
The estimate for compound 4 lay 2.0-fold (0.30 log units) above the measured number, and the stated range covers the measured number.
By their numbers in this assay, from the lowest: compound 4; then compounds 1 and 3 (each within the scatter of the next). At a limit, below all of these: compound 2.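

Among these compounds, with phenoxy and anilino on the core of compound 1, this position gives the first measured step in the set: in this assay, the change gives a 2.7-fold lower number from compound 1 to compound 4 (0.43 log units; beyond the scatter). This shows that the read-out responds to this change on an aromatic carbon, even though both groups have 7 heavy atoms and one six-membered aromatic ring of carbon only. The counted differences are nitrogen for oxygen and the hydrogen-bond donor that enters, but nothing measured here ties the step to either of them.

One pair leaves open whether the step would recur on the other cores shown. It also leaves open how a methylated anilino, which keeps the nitrogen without its hydrogen, or a benzylamino group would read at this position.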